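The source may report more compounds than this note shows. Statements on the series, on what has been measured and on what is new or still open speak of the compounds shown alone.

The measured compounds:
compound 1, `O=C(Nc1ccc(Cl)c(-c2nnc3c(Cl)cccn23)c1)c1cccnc1`: > 100000 nM
compound 2, `O=C(Nc1ccc(Cl)c(-c2nnc3c(Cl)cccn23)c1)c1ccc(C(F)(F)F)cc1F`: > 100000 nM
compound 3, `O=C(Nc1ccc(Cl)c(-c2nnc3c(Cl)cccn23)c1)c1ccon1`: > 100000 nM

All three share one core and differ only in the group attached to the carbonyl carbon of the amide. In a functional assay on MDA-MB-231 cells (Homo sapiens) for antiproliferative activity, read by MTT assay, with stated times of 72 h and 4 h (on this read-out lower numbers stand for stronger inhibition and higher numbers for weaker inhibition), compound 1 gives > 100000 nM, which is a limit of the assay rather than a number. Compound 2 likewise gives > 100000 nM, a limit. Compound 3 gives > 100000 nM, again a limit. Because (the limit of > 100000 nM in this assay, at which 3 of the 3 values shown sit), no measured step can be read: a step that the two limits leave unreadable from compound 1 to compound 3. Where compound 1 stands in this assay is therefore known only as a limit, and no step to or from it has a readable size.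

Compound 4, `O=C(Nc1ccc(Cl)c(-c2nnc3c(Cl)cccn23)c1)c1c(F)cccc1Cl`, has not yet been measured. It differs from compound 1 in one place: 2-chloro-6-fluorophenyl in place of pyridin-3-yl on a carbonyl carbon. Among the compounds with values here, the only measured step that touches compound 1 is unreadable, so it gives no guidance on direction or size, and compounds 2 and 3 show only that two other groups on the same carbonyl carbon also stayed at a limit. The expectation for compound 4 is thus no readable step beyond the scatter, and compound 4 is estimated at 100000 nM, between 30000 nM and 300000 nM. As a step from compound 1 this estimate is expected to come out as a number no higher from compound 1 to compound 4 (the limit leaves the size open).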

Compound 4, half-maximal inhibitory concentration: > 100000 nM
Compound 4 gave a limit, no number; the forecaster's own chance of this, stated with the estimate: 80%; the middle value lies on the limit itself.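

Compound 4 also gives a limit rather than a number, so the steps from compound 1 to compound 4 and from compound 3 to compound 4 cannot be read: the limit of > 100000 nM in this assay, at which 4 of the 4 values shown sit.

Left open is how strongly any of the four compounds acts in this assay and whether the group on the carbonyl carbon makes any difference there.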